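A few compounds are considered here, and "the series" means these few. Any claim that something is new, unique, unknown or untested is made for them only; others in the source may bear on it.

Compound 1 `COc1cccc(OC)c1OCCNCCOc1ccccc1OCc1ccccc1Cl`: 0.562 nM
Compound 2 `COc1cccc(OC)c1OCCNCCOc1ccccc1OCc1cccc(Cl)c1`: 0.159 nM
Compound 3 `COc1cccc(OC)c1OCCNCCOc1ccccc1OCc1cccc(C)c1`: 0.251 nM

In an assay on CHO cells for displacement of a labelled ligand from Alpha-1B adrenergic receptor (Homo sapiens) (a lower number here means a stronger inhibitor, a higher number a weaker inhibitor), compound 1 gives the highest number of the three measured compounds: there is a 3.5-fold lower number from compound 1 to compound 2 (0.55 log units; beyond the scatter) and a 2.2-fold lower number from compound 1 to compound 3 (0.35 log units; beyond the scatter), while between the other two there is a 1.6-fold higher number from compound 2 to compound 3 (0.20 log units; within the scatter). Compound 4 `COc1ccccc1COc1ccccc1OCCNCCOc1c(OC)cccc1OC` keeps the core of compound 1 and differs by a single change: methoxy in place of chloro on an aromatic carbon. Among the measured compounds shown here, no measured step makes this exact exchange; the two steps beyond the scatter move the group to another ring carbon rather than exchange it in place, and the one in-place exchange measured stays within the scatter. The step expected for compound 4 is therefore small, a 1.1-fold lower number from compound 1 to compound 4 (0.05 log units; within the scatter). Compound 4 is estimated in this assay at 0.5 nM, within a range from 0.18 nM to 1.4 nM.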

Compound 4, inhibition constant: 6.31 nM
The estimate for compound 4 lay 13-fold (1.10 log units) below the measured number, and the stated range ends below it.
By their numbers in this assay, from the lowest: compounds 2 and 3 (each within the scatter of the next); then compound 1; then compound 4.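

In this assay, among the compounds shown here, the exchange of chloro for methoxy on this aromatic carbon proves far from neutral (an 11-fold higher number from compound 1 to compound 4 (1.05 log units; beyond the scatter)), although the one earlier in-place exchange, methyl for chloro on a different ring carbon, stayed within the scatter (a 1.6-fold higher number from compound 2 to compound 3 (0.20 log units; within the scatter)). The 2-methoxyphenyl group also stands well behind both 3-substituted phenyl groups (a 25-fold higher number from compound 3 to compound 4 (1.40 log units; beyond the scatter); a 40-fold higher number from compound 2 to compound 4 (1.60 log units; beyond the scatter)). Nothing available bears on the reason for this shift. Going by these compounds, whether methoxy on another ring carbon, or a hydroxy or ethoxy group on this one, would give a similar number remains open.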